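The source may hold more compounds than are shown below. What is called first, only, known or untested is meant among the compounds shown, and "the series" means these compounds.

Measured compounds:
- compound 1 `Sc1nc(NCc2ccccc2)c2ccccc2n1`: > 100000 nM
- compound 2 `CCCCCSc1nc(NCc2ccc([Se]C)cc2)c2ccccc2n1`: > 100000 nM
- compound 3 `CSc1nc(NCc2ccc([Se]C)cc2)c2ccccc2n1`: > 100000 nM

In a functional assay on MCF7 cells (Homo sapiens) for cytotoxicity, read by MTT assay, with a stated time of 72 h (on this read-out lower numbers stand for higher toxicity in this test and higher numbers for lower toxicity in this test), compound 3 gives > 100000 nM, and this figure is a limit of the assay rather than a number. Compound 2 also reaches only a limit, > 100000 nM. Compound 1 likewise stops at a limit, > 100000 nM. All three measured values therefore sit at the same limit (the limit of > 100000 nM in this assay, at which 3 of the 3 values shown sit), and compound 3 cannot be placed relative to the others.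

Compound 4 `CSc1nc(NCc2ccccc2)c2ccccc2n1` differs from compound 3 by a hydrogen atom in place of a group of 2 heavy atoms (1 carbon, 1 selenium; no ring), on an aromatic carbon. Among the compounds with values here, the only measured step that can be compared, a step that the two limits leave unreadable from compound 2 to compound 3, changes a group on the sulfur-bound chain rather than the aromatic ring, and its size cannot be read from two limits. Within the data shown here, no measured step speaks directly to removing the selenium-bearing group, and no trend beyond the scatter can be claimed.

Compound 4 is therefore expected to remain at the limit, an estimated 150000 nM with a range from 50000 nM to 500000 nM, meaning an expected step that the limit leaves unreadable from compound 3 to compound 4.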

Compound 4, concentration lethal to 50% of the cells: > 100000 nM
Compound 4: no number, only a limit (the forecaster's own chance of this, stated with the estimate: 85%); the middle value does not contradict the limit.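

The steps from compound 1 to compound 4 and from compound 3 to compound 4 cannot be read, as both ends of each are limits rather than numbers: the limit of > 100000 nM in this assay, at which 4 of the 4 values shown sit.

The compounds shown leave open whether the methyl-and-selenium group or the chain on sulfur matters at all in this assay.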